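This account rests on a few compounds, and the source may have more. Where it says the series, first, only, none or still open, it means among the compounds named here.

Measured in a functional assay on A549 cells (Homo sapiens) for inhibition, read by CCK-8 assay, with a stated time of 48 h; a higher number here means a weaker inhibitor, a lower number a stronger inhibitor:
- compound 1 `COc1cc(-c2ccnc3cc(-c4c[nH]c5ccccc45)nn23)cc(OC)c1OC`: 29 nM
- compound 2 `COc1cc(-c2ccnc3cc(-c4ccc5c(ccn5C)c4)nn23)cc(OC)c1OC`: 15 nM

Compound 2, at 15 nM, stands level with compound 1, at 29 nM, since the two numbers lie within the scatter of each other. The next compound, compound 3 `COc1cc(-c2ccnc3cc(-c4ccc5cc[nH]c5c4)nn23)cc(OC)c1OC`, keeps the shared core but has 1H-indol-6-yl in place of 1-methyl-1H-indol-5-yl on an aromatic carbon. 1H-indol-6-yl in place of 1-methyl-1H-indol-5-yl on an aromatic carbon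

Among the measured compounds shown here, only one measured step bears on this change: a 1.9-fold lower number from compound 1 to compound 2 (0.29 log units; within the scatter). That step also exchanged one indolyl group for another, and it stayed within the scatter. For the measured compounds named here, it is a single step, and no measured pair isolates the 1-methyl group or the 6-yl attachment on its own. The data therefore give no firm direction, and no shift beyond the scatter is expected in this assay. The expected step, a small one, is a 1.7-fold higher number from compound 2 to compound 3 (0.22 log units; within the scatter). For compound 3 the estimated value is 25 nM, with an expected range from 8 nM to 80 nM.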

Compound 3, half-maximal inhibitory concentration: 170 nM
For compound 3 the middle estimate is 6.8-fold (0.83 log units) below the measured one, and the stated range ends below it.
By their numbers in this assay, from the lowest: compounds 2 and 1 (each within the scatter of the next); then compound 3.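

In this assay, the indolyl group at this position proves not to be freely exchangeable, although the earlier pair suggested it might be: 1H-indol-6-yl in place of 1-methyl-1H-indol-5-yl gives an 11-fold higher number from compound 2 to compound 3 (1.05 log units; beyond the scatter). The comparison with compound 1 is the more telling one, since both groups there are unmethylated indoles and they differ only in the point of attachment, and 1H-indol-6-yl in place of 1H-indol-3-yl gives a 5.9-fold higher number from compound 1 to compound 3 (0.77 log units; beyond the scatter), so the loss at compound 3 does not follow simply from having a free indole hydrogen, which compound 1 also carries. Nothing available here explains why the attachment point should matter in this way.

The step from compound 2 to compound 3 changes the methyl group and the attachment point together, so the share of each remains unresolved, and 1-methyl-1H-indol-6-yl or 1H-indol-5-yl at the same place would be needed to separate them. Also open, as far as these compounds go, is how the 6-yl attachment would respond to a further substituent on the indole, such as a methoxy group or an amine.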